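From phenyl to 3,4-dichlorophenyl on compound 3

A few compounds are considered here, and "the series" means these few. Any claim that something is new, unique, unknown or untested is made for them only; others in the source may bear on it.

Compound 1 `O=C1NC(=O)/C(=C\c2ccc(OCC(=O)N3N=C(c4ccccc4)CC3c3ccc(C(F)(F)F)cc3)cc2)S1`: > 10000 nM
Compound 2 `O=C1NC(=O)/C(=C\c2ccc(OCC(=O)N3N=C(c4ccccc4)CC3c3ccc(Cl)c(Cl)c3)cc2)S1`: > 10000 nM
Compound 3 `O=C1NC(=O)/C(=C\c2ccc(OCC(=O)N3N=C(c4ccc(F)cc4)CC3c3ccccc3)cc2)S1`: > 10000 nM

All three compounds were tested in a toxicity assay on HUVEC cells (Homo sapiens) for cytotoxicity, read by MTT assay, with a stated time of 96 h (on this read-out higher numbers stand for weaker inhibition and lower numbers for stronger inhibition), and each entry above is a limit rather than a number. Compound 3 stands at > 10000 nM, which is a limit. It therefore has no readable rank among the others. Among the compounds with values here, the series so far sits at a single mark: the limit of > 10000 nM in this assay, at which 3 of the 3 values shown sit.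

Compound 4 `O=C1NC(=O)/C(=C\c2ccc(OCC(=O)N3N=C(c4ccc(F)cc4)CC3c3ccc(Cl)c(Cl)c3)cc2)S1` keeps the 4-fluorophenyl group of compound 3 and takes 3,4-dichlorophenyl in place of phenyl on a saturated ring carbon, next to the ring nitrogen: 3,4-dichlorophenyl in place of phenyl on a saturated ring carbon.

Within the data shown here, the one measured step that bears on this change is a step that the two limits leave unreadable from compound 1 to compound 2. It brings in the same group at the same place, but offers no size to carry over. Compound 2, which carries that group, remains at > 10000 nM, again a limit. No step beyond the scatter is therefore expected in this assay, no direction can be given, and compound 4 is expected to be reported as a limit too. The estimated step is a step that the limit leaves unreadable from compound 3 to compound 4. For compound 4 the estimate is 12000 nM, with an expected range from 6000 nM to 30000 nM.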

Compound 4, half-maximal inhibitory concentration: 2000 nM
Compound 4: middle estimate off by 6.0-fold (0.78 log units), on the high side, outside the stated range (below it).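

In this assay, the change to 3,4-dichlorophenyl on the saturated ring carbon now has a readable direction when the 4-fluorophenyl group is present, giving an at least 5.0-fold lower number from compound 3 to compound 4 (0.69 log units; beyond the scatter). The same comparison seen from the other side shows that the fluoro in place of hydrogen on an aromatic carbon also matters once 3,4-dichlorophenyl is present, giving an at least 5.0-fold lower number from compound 2 to compound 4 (0.69 log units; beyond the scatter). Each group alone leaves its compound at a limit, and only compound 4, which carries both, has a measured number, so it alone stands apart from the shared mark: the limit of > 10000 nM in this assay, at which 3 of the 4 values shown sit.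

As far as these compounds go, the step between compound 1 and compound 2 cannot be read, and the full size of the two new steps stays open, as both start from a limit. From the compounds shown here alone, it also remains open whether chloro, methoxy or an amine in place of the fluoro of the 4-fluorophenyl group would, alongside 3,4-dichlorophenyl, give a similar number, and whether 4-(trifluoromethyl)phenyl could stand in for 3,4-dichlorophenyl in that pairing.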